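The compounds below may be only part of what the source reports. "The series", "measured", "known", "first", "only" and "open" are said of these compounds alone.

Two compounds of this series have numbers in a functional assay on HOP-62 cells (Homo sapiens) for inhibition, read by sulforhodamine B assay, with a stated time of 48 h; on this read-out higher numbers stand for weaker inhibition of growth and lower numbers for stronger inhibition of growth. Compound 1 `COc1ccc(-c2[nH]c3ccc(OC)cc3c2/C=C(\C#N)S(=O)(=O)c2ccccc2)cc1` gives 3100 nM. Compound 2 `CC(=O)/C(=C\c1c(-c2ccccc2)[nH]c2ccccc12)S(=O)(=O)c1ccccc1` gives 1200 nM, the lowest of the two numbers, and its gap to compound 1 lies beyond the scatter. Compound 3 `N#C/C(=C\c1c(-c2ccccc2)[nH]c2ccccc12)S(=O)(=O)c1ccccc1` is not yet measured. It differs from compound 2 by cyano in place of acetyl on a double-bonded chain carbon bound to a double-bonded chain carbon and a sulfonyl sulfur. Among the measured compounds shown here, no measured pair isolates this change, so only a small step is expected, toward weaker inhibition or none beyond the scatter. Compound 3 is estimated at 1800 nM, with a range from 600 nM to 5500 nM. This expectation corresponds to a step of a 1.5-fold higher number from compound 2 to compound 3 (0.18 log units; within the scatter) in this assay.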

Compound 3, concentration for 50% growth inhibition: 9300 nM
Compound 3: middle estimate off by 5.2-fold (0.71 log units), on the low side; measured number outside the range, above it.
By their numbers in this assay, from the lowest: compound 2; then compound 1; then compound 3.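

In this assay, the double-bonded chain carbon bound to a double-bonded chain carbon and a sulfonyl sulfur proves sensitive to its substituent: cyano in place of acetyl gives a 7.8-fold higher number from compound 2 to compound 3 (0.89 log units; beyond the scatter), so the two groups are not interchangeable here. On this pair, acetyl is the better of the two for inhibition of growth. No data at hand account for the step. From the compounds shown here alone, whether a methyl ester or a primary amide at this carbon would match acetyl remains open. So does whether the step carries over to the core of compound 1.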